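Swapping the dichlorophenyl acyl group for a fluorophenyl group

This account rests on a few compounds, and the source may have more. Where it says the series, first, only, none or still open, it means among the compounds named here.

Compound 2 `CN(C(=O)NC(=O)c1ccc(Cl)cc1Cl)c1nc(C(F)(F)F)c(C(=O)N/N=C/c2ccc(C(F)(F)F)cc2)s1` gives 3.08 ug/mL in a functional assay on BCG823 cells (Homo sapiens) for inhibition, read by MTT assay, with a stated time of 72 h; a higher number here means a weaker inhibitor, a lower number a stronger inhibitor. Its number sits with that of compound 1 `CN(C(=O)NC(=O)c1ccc(Cl)cc1Cl)c1nc(C(F)(F)F)c(C(=O)N/N=C/c2cccc(C(F)(F)F)c2)s1`, which gives 6.11 ug/mL, since a 2.0-fold lower number from compound 1 to compound 2 (0.30 log units; within the scatter). It stands well apart from compound 3 `Cc1nc(N(C)C(=O)NC(=O)c2ccc(Cl)cc2Cl)sc1C(=O)N/N=C/c1ccc(C(F)(F)F)cc1`, which gives 38 ug/mL, as a 12-fold higher number from compound 2 to compound 3 (1.09 log units; beyond the scatter). Compound 4 `CN(C(=O)NC(=O)c1ccccc1F)c1nc(C(F)(F)F)c(C(=O)N/N=C/c2ccc(C(F)(F)F)cc2)s1` differs from compound 2 in one place: 2-fluorophenyl in place of 2,4-dichlorophenyl on a carbonyl carbon. For the measured compounds named here, neither measured step touches this part of the molecule, so no direct guide exists; the second step shows only that a single change on the shared core can be large. With little to rest on, a modest move toward a higher number is expected for compound 4, a 1.8-fold higher number from compound 2 to compound 4 (0.25 log units; within the scatter). Compound 4 is therefore estimated at 5.5 ug/mL, within a range from 1.5 ug/mL to 20 ug/mL.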

Compound 4, half-maximal inhibitory concentration: 3.87 ug/mL
For compound 4 the middle estimate is 1.4-fold (0.15 log units) above the measured one; measured number inside the range.
By their numbers in this assay, from the lowest: compounds 2, 4 and 1 (each within the scatter of the next); then compound 3.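

In this assay, the acyl position of the shared core accepts 2-fluorophenyl in place of 2,4-dichlorophenyl with no readable difference (a 1.3-fold higher number from compound 2 to compound 4 (0.10 log units; within the scatter)). This contrasts with the large step seen on the shared core when methyl replaces trifluoromethyl (a 12-fold higher number from compound 2 to compound 3 (1.09 log units; beyond the scatter)). At this carbonyl carbon, then, the two chlorines can give way to one fluorine while the aromatic ring stays in place.

As far as these compounds go, whether the ring itself is needed stays open, as does the outcome with a group such as cyclohexyl or a longer alkyl chain, or with an amine on the ring. No measurement shown accounts for how little this swap changes the number.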